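Thiophene in Place of Furan on a Second Core

The source may report more compounds than this note shows. Statements on the series, on what has been measured and on what is new or still open speak of the compounds shown alone.

Compound 1 `c1ccc(C(/N=C2\CCCCN2)c2ccco2)cc1` and compound 3 `c1ccc(C(/N=C2\CCCCN2)c2cccs2)cc1` share a core, and in a functional assay on the whole organism (plasma, strain Sprague-Dawley) with Rattus norvegicus as the target, with a stated time of 2 h, at a dose of 25 mg/kg by the oral route (a lower number here means a weaker effect, a higher number a stronger effect of the compound at the dose given), compound 1 gives 10% while compound 3 gives 31%. The change between them is thiophen-2-yl in place of furan-2-yl on a saturated chain carbon bound to an aromatic carbon and a double-bonded nitrogen, and it made a step of a number 21 percentage points higher from compound 1 to compound 3 (beyond the scatter). Compound 2 `c1ccc(C(/N=C2\CCCCCN2)c2ccco2)cc1` carries a different core; how the two cores differ is not broken down here. In this assay compound 2 gives 34%, a number close to that of compound 3. Compound 4 `c1ccc(C(/N=C2\CCCCCN2)c2cccs2)cc1` has not yet been measured. Within the data shown here, it differs from compound 2 by thiophen-2-yl in place of furan-2-yl on a saturated chain carbon bound to an aromatic carbon and a double-bonded nitrogen, which is the same change as the one from compound 1 to compound 3, made at the same place. Because the step of a number 21 percentage points higher from compound 1 to compound 3 (beyond the scatter) came from that change, a step of similar size is expected for compound 2, namely a number 18 percentage points higher from compound 2 to compound 4 (beyond the scatter). This rests on one earlier example only, on a core that is not the same, so the expectation is loose. Compound 4 is therefore expected to give 52% in this assay, with a likely range from 32% to 72%.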

Compound 4, a percentage reported as inhibition, in the whole organism at one dose (the size of the read-out at that dose, not a potency): 36%
Beside the measured number, compound 4's estimate is 16 percentage points above it; the range from low to high includes it.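

The change from furan-2-yl to thiophen-2-yl did not carry over from one core to the other in this assay, as the two steps set side by side make clear: the same change on two cores in this assay, a number 21 percentage points higher (beyond the scatter) from compound 1 to compound 3 and a number 2 percentage points higher (within the scatter) from compound 2 to compound 4, 19 percentage points apart, beyond the scatter of two such steps. On the second core the change gave a step of a number 2 percentage points higher from compound 2 to compound 4 (within the scatter), so the earlier gain did not reappear and the two compounds on this core cannot be told apart in this read-out. This does not show why the two cores respond differently, and with a single pair on each core, tested at one dose, it gives no general rule about either core or about this change.

The compounds shown leave open how the same change would behave on any further core. They also leave open what an amine or a carboxylic acid would do in place of these two groups on a saturated chain carbon bound to an aromatic carbon and a double-bonded nitrogen.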